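The compounds below may be only part of what the source reports. "The series", "measured", "known", "first", "only" and "open" are said of these compounds alone.

Three compounds were measured in a functional assay on the whole organism (blood) with Rattus norvegicus as the target, with stated times of 24 h and 1 h, at a dose of 15 mg/kg by the intraperitoneal route; on this read-out lower numbers stand for a weaker effect and higher numbers for a stronger effect at the one dose given:
compound 1 `CC(=O)NCCC1CCN(S(=O)(=O)NC(=O)NC[C@@H]2C[C@@H]3C=C[C@@H]2C3)CC1` gives 25%;
compound 2 `COc1ncccc1C(=O)NCCC1CCN(S(=O)(=O)NC(=O)NC2CCCCC2)CC1` gives 35%;
compound 3 `COc1ccc(C(=O)NCCC2CCN(S(=O)(=O)NC(=O)NC[C@@H]3C[C@@H]4C=C[C@@H]3C4)CC2)cn1` gives 32%.

Compound 3 stands second highest of these three numbers. Its nearest neighbour is compound 2, whose number lies within the scatter of it; its furthest is compound 1, where a number 7 percentage points higher from compound 1 to compound 3 (within the scatter). Compound 4 `O=C(NC[C@@H]1C[C@@H]2C=C[C@@H]1C2)NS(=O)(=O)N1CCC(CCNC(=O)c2nc3ccccc3s2)CC1` differs from compound 3 in one place: 1,3-benzothiazol-2-yl in place of 6-methoxypyridin-3-yl on a carbonyl carbon. For the measured compounds named here, the only measured step that bears on this is the one from compound 1 to compound 3, which likewise exchanged a group on a carbonyl carbon and stayed within the scatter; for compound 4 no step beyond the scatter is therefore expected in this assay. Compound 4 is expected to give 33%, with a range from 20% to 46%. The estimated step is a number 1 percentage points higher from compound 3 to compound 4 (within the scatter), in no clear direction.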

Compound 4, a percentage reported as activity, at one dose (the size of the read-out at that dose, not a potency): 34%
Compound 4: the middle estimate sits 1 percentage points below what was measured, and the stated range covers the measured number.
By their numbers in this assay, from the lowest: compounds 1, 3, 4 and 2 (each within the scatter of the next).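

In this assay the place on a carbonyl carbon next to the amide-type nitrogen now tolerates a third group with no readable change: 1,3-benzothiazol-2-yl in place of 6-methoxypyridin-3-yl gives (a number 2 percentage points higher from compound 3 to compound 4 (within the scatter)). The same group in place of methyl gives (a number 9 percentage points higher from compound 1 to compound 4 (within the scatter)), so even the two aromatic rings that enter leave the number within the scatter of the methyl compound. No evidence bears on why this place responds so little. From the compounds shown here alone, whether any group here can move the number beyond the scatter remains open, including a carboxylic acid or an amine at this carbonyl carbon.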